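This account rests on a few compounds, and the source may have more. Where it says the series, first, only, none or still open, it means among the compounds named here.

Measured so far in an ADME assay for permeability, using PAMPA, with a stated time of 30 min, at pH 7.4; on this read-out lower numbers stand for lower permeability and higher numbers for higher permeability:

compound 1 `COc1ccccc1Oc1ccc2c(NCCCNCc3cccc(OC)c3O)ccnc2c1` gives 317 10^-6 cm/s
compound 2 `COc1ccc(F)cc1CNCCCNc1ccnc2cc(-c3ccc(C(F)(F)F)cc3)ccc12` gives 237 10^-6 cm/s
compound 3 `COc1ccc(F)cc1CNCCCNc1ccnc2cc(Oc3ccccc3OC)ccc12` gives 317 10^-6 cm/s

The change from compound 3 to compound 1 is 2-hydroxy-3-methoxyphenyl in place of 5-fluoro-2-methoxyphenyl on a saturated chain carbon bound to an amine nitrogen. Its step was no change at the digits printed from compound 3 to compound 1 (within the scatter). Compound 2 and compound 3 differ at the core by 4-(trifluoromethyl)phenyl in place of 2-methoxyphenoxy on an aromatic carbon, and that step was a 1.3-fold higher number from compound 2 to compound 3 (0.13 log units; within the scatter). All three numbers therefore sit within the usual scatter of one another.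

Compound 4 `COc1cccc(CNCCCNc2ccnc3cc(-c4ccc(C(F)(F)F)cc4)ccc23)c1O` is not yet measured. It differs from compound 2 by 2-hydroxy-3-methoxyphenyl in place of 5-fluoro-2-methoxyphenyl on a saturated chain carbon bound to an amine nitrogen, the same change at the same place as from compound 3 to compound 1, now on the core of compound 2. The step from compound 2 to compound 4 is expected to be a 1.0-fold higher number from compound 2 to compound 4 (0.01 log units; within the scatter), resting on the earlier step of no change at the digits printed from compound 3 to compound 1 (within the scatter) and on the value of compound 2 237 10^-6 cm/s. For compound 4 in this assay the estimate is 240 10^-6 cm/s, expected to fall between 150 10^-6 cm/s and 380 10^-6 cm/s.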

Compound 4, apparent permeability: 237 10^-6 cm/s
Estimate against measurement, compound 4: 1.0-fold (0.01 log units) above; the range from low to high includes it.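

In this assay, 2-hydroxy-3-methoxyphenyl in place of 5-fluoro-2-methoxyphenyl on the core of compound 2 gave no change at the digits printed from compound 2 to compound 4 (within the scatter), and this step matches the one seen on the other core: the same change on two cores in this assay, no change at the digits printed (within the scatter) from compound 3 to compound 1 and no change at the digits printed (within the scatter) from compound 2 to compound 4, 1.0-fold (0.00 log units) apart, within the scatter of two such steps

The other exchange, 4-(trifluoromethyl)phenyl in place of 2-methoxyphenoxy on an aromatic carbon, gave a 1.3-fold lower number from compound 1 to compound 4 (0.13 log units; within the scatter), which also matches its earlier counterpart: the same change on two cores in this assay, a 1.3-fold higher number (0.13 log units; within the scatter) from compound 2 to compound 3 and a 1.3-fold higher number (0.13 log units; within the scatter) from compound 4 to compound 1, 1.0-fold (0.00 log units) apart, within the scatter of two such steps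

Each comparison rests on a single pair of steps, all within the scatter, so the agreement does not show that a step beyond the scatter would carry from one core to another.

The compounds shown leave open whether the match holds for a carboxylic acid or an amine on that aromatic carbon, or for a longer chain.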